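Replacing ethoxycarbonyl with 4-chlorophenyl in compound 3

The source may report more compounds than this note shows. Statements on the series, on what has been measured and on what is new or still open speak of the compounds shown alone.

Of the compounds shown here, three have been tested in an ADME assay on HEK293 cells (Homo sapiens) for cytotoxicity, with a stated time of 72 h (a lower number here means that less compound is needed, a higher number that more compound is needed for the effect), and none has yet given a number. Compound 1 (`C=C[C@@](C)(/C=C/c1ccc(OS(=O)(=O)c2ccc(C)cc2)cc1)CCC=C(C)C`) reads > 36600 nM as a limit of the assay. Compound 2 (`C=C[C@@](C)(/C=C/c1ccc(O)cc1)CC/C=C(C)/C=C/C(=O)OCC`) reads > 36600 nM as a limit too. Compound 3 (`C=C[C@@](C)(/C=C/c1ccc(O)c(/C=C/C(=O)OCC)c1)CCC=C(C)C`) reads > 36600 nM as a limit as well. It therefore stands with the other two, and the whole set comes down to the limit of > 36600 nM in this assay, at which 3 of the 3 values shown sit, alone.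

Compound 4 (`C=C[C@@](C)(/C=C/c1ccc(O)c(/C=C/c2ccc(Cl)cc2)c1)CCC=C(C)C`) has still to be measured in this assay. Its difference from compound 3 is this (4-chlorophenyl in place of ethoxycarbonyl on a double-bonded chain carbon bound to a double-bonded chain carbon): 4-chlorophenyl in place of ethoxycarbonyl on a double-bonded chain carbon bound to a double-bonded chain carbon. Among the compounds with values here, no measured step sizes such an exchange, and the only anchor is compound 3 with > 36600 nM as a limit.

A modest move toward less compound needed is expected, an estimated at least 1.2-fold lower number from compound 3 to compound 4 (0.08 log units; that floor lies within the scatter) in size, and the reading may again be only a limit. The expected value for compound 4 is 30000 nM within an estimated range (from 10000 nM to 40000 nM).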

Compound 4, half-maximal effective concentration: > 36600 nM
Compound 4: only a limit was reported; the forecaster's own chance of this, stated with the estimate: 60%; middle value at least 1.2-fold (0.08 log units) away from the limit.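

Within the data shown here, compound 3 and compound 4 both stop at a limit in this assay, so no step between them can be read, and the exchange of ethoxycarbonyl for 4-chlorophenyl remains without a measured size. The compounds shown leave open what number any of them would give, since all share one reading: the limit of > 36600 nM in this assay, at which 4 of the 4 values shown sit.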